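Cytotoxicity after Swapping the Amide Aryl Group

The compounds below may be only part of what the source reports. "The series", "measured", "known", "first", "only" and "open" are said of these compounds alone.

Among the measured compounds shown here, compound 3 `COc1cc2nc([S+]([O-])CC(=O)Nc3ccc([N+](=O)[O-])cc3)nc(Nc3c(Cl)cc(/C=C/C#N)cc3Cl)c2cc1OC` gives 92800 nM in an ADME assay on MT4 cells (Homo sapiens) for cytotoxicity, read by MTT assay, with a stated time of 5 days (a higher number here means that more compound is tolerated, a lower number that less compound is tolerated), the lowest of the two numbers known here; compound 2 `COc1cc2nc([S+]([O-])CC(=O)Nc3ccc([N+](=O)[O-])cc3)nc(Nc3c(C)cc(/C=C/C#N)cc3C)c2cc1OC` gives 189000 nM, and the step of a 2.0-fold lower number from compound 2 to compound 3 (0.31 log units; beyond the scatter) exchanges a group on a nitrogen on an aromatic ring. Compound 1 `COc1cc2nc(SCC(=O)Nc3cccc(S(N)(=O)=O)c3)nc(Nc3c(Cl)cc(/C=C/C#N)cc3Cl)c2cc1OC` reaches only the limit > 194000 nM in this assay, and the limit of > 194000 nM in this assay, at which 1 of the 3 values shown sits, marks where that limit sits. Compound 4 `COc1cc2nc([S+]([O-])CC(=O)Nc3cccc(C#N)c3)nc(Nc3c(Cl)cc(/C=C/C#N)cc3Cl)c2cc1OC` differs from compound 3 by 3-cyanophenyl in place of 4-nitrophenyl on an amide-type nitrogen. For the measured compounds named here, no measured step touches this part of the molecule, so the single known step offers no direct guidance; a change on the amide-type nitrogen is expected to give no step beyond the scatter in this assay. Compound 4 is therefore estimated at 110000 nM, within a range of 50000 nM to 250000 nM, which means an expected step of a 1.2-fold higher number from compound 3 to compound 4 (0.07 log units; within the scatter).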

Compound 4, half-maximal cytotoxic concentration: >= 70300 nM
Compound 4: only a limit was reported; the forecaster's own chance of this, stated with the estimate: 30%; the middle value does not contradict the limit.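

In this assay compound 4 gives >= 70300 nM, which is a limit and not a number, so the step from compound 3 to compound 4 cannot be read. The compounds shown leave open whether 3-cyanophenyl in place of 4-nitrophenyl on the amide-type nitrogen changes how much compound is tolerated.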